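The compounds below may be only part of what the source reports. "The series", "measured", "known", "first", "only" and "open" are said of these compounds alone.

Measured so far in a functional assay on THP-1 cells (Homo sapiens) for inhibition; on this read-out higher numbers stand for weaker inhibition and lower numbers for stronger inhibition:
- compound 1 `COc1cccc(-c2nnnn2Cc2ccccc2Cl)c1OC`: > 10000 nM
- compound 2 `Clc1cccc(-n2nnnc2Cc2cccnc2)c1Cl`: 398 nM
- compound 3 `FC(F)(F)c1cccc(-n2nnnc2Cc2cccnc2)c1Cl`: 50.1 nM

The entry for compound 1 is a limit, not a number. Of the two actual numbers, compound 3 holds the lower, 50.1 nM, and compound 2 the higher, 398 nM.

Compound 4 `Fc1ccc(-n2nnnc2Cc2cccnc2)c(Cl)c1C(F)(F)F` carries fluoro in place of hydrogen on an aromatic carbon, ortho to a trifluoromethyl group: fluoro in place of hydrogen on an aromatic carbon. Among the measured compounds shown here, only one measured step is available as a guide: a 7.9-fold lower number from compound 2 to compound 3 (0.90 log units; beyond the scatter), with trifluoromethyl in place of chloro. It bears on the new change only loosely, as it exchanged a different group. For the measured compounds named here, no measured step shows what fluoro in place of hydrogen does here, so its size is uncertain and a wide range is needed.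

No step beyond the scatter is expected in this assay, and no direction is favoured. The expected step is a 1.1-fold lower number from compound 3 to compound 4 (0.05 log units; within the scatter). Compound 4 is estimated at 45 nM, with an expected range from 14 nM to 150 nM.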

Compound 4, half-maximal inhibitory concentration: 158 nM
Beside the measured number, compound 4's estimate is 3.5-fold (0.55 log units) below it, and the stated range ends below it.
By their numbers in this assay, from the lowest: compound 3; then compound 4; then compound 2. At a limit, above all of these: compound 1.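

In this assay the aromatic carbon ortho to a trifluoromethyl group and meta to a chloro group proves sensitive to change: fluoro in place of hydrogen there brings a 3.2-fold higher number from compound 3 to compound 4 (0.50 log units; beyond the scatter) and so weaker inhibition. Among the compounds shown here, until now the only readable step was the exchange of one group for another, a 7.9-fold lower number from compound 2 to compound 3 (0.90 log units; beyond the scatter), and it went towards stronger inhibition; this new step shows that even a single added fluorine atom on this ring can move the number the opposite way. No measurement shown here explains why this happens.

Going by these compounds, it remains open whether this loss belongs to fluoro itself or to any group on this carbon, which a methyl group, a methoxy group or an amine there would help to separate. On these data alone, it is also open whether fluoro on the other carbons of this ring would act in the same way.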